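A few compounds are considered here, and "the series" means these few. Any claim that something is new, unique, unknown or untested is made for them only; others in the source may bear on it.

Working notes on the series. Three compounds carry numbers in an ADME assay on HepG2 cells (Homo sapiens) for cytotoxicity, read by luminescence, CellTiter-Glo and ATP content, with a stated time of 72 h; on this read-out lower numbers stand for an effect already at smaller amounts and higher numbers for an effect only at larger amounts of compound. Compound 1 `COc1ccccc1Oc1ccc2c(NCCCNCc3ccco3)ccnc2c1` gives 6500 nM in this assay , the highest of the three. Compound 2 `COc1ccc(F)cc1CNCCCNc1ccnc2cc(Cc3ccc(C#N)cc3)ccc12` gives 6050 nM, which sits within the scatter of compound 1, so no order between the two is read. Compound 3 `COc1cccc(CNCCCNc2ccnc3cc(Cc4cccc(C(F)(F)F)c4)ccc23)c1O` gives 1720 nM, a number beyond the scatter below that of compound 1. No step between measured compounds that differ in one place is shown, so the weight of any single change is unknown here.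

Compound 4 `CN(C)c1cccc(Oc2ccc3c(NCCCNCc4ccco4)ccnc3c2)c1` is the next compound to be measured. It differs from compound 1 as follows: 3-(dimethylamino)phenyl in place of 2-methoxyphenyl on an oxygen on an aromatic ring. Both groups that leave and enter are neutral, each with one hydrogen-bond acceptor and no donor, on the same oxygen.

With no comparable step shown, the step from compound 1 to compound 4 in this assay is expected to be a 1.3-fold lower number from compound 1 to compound 4 (0.11 log units; within the scatter), no larger than the scatter, as the three numbers shown all lie close together. Compound 4 is estimated at 5000 nM, in the range 2000 nM to 12000 nM.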

Compound 4, half-maximal effective concentration: 16000 nM
Beside the measured number, compound 4's estimate is 3.2-fold (0.51 log units) below it, outside the stated range (above it).
By their numbers in this assay, from the lowest: compound 3; then compounds 2 and 1 (each within the scatter of the next); then compound 4.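

In this assay, 3-(dimethylamino)phenyl in place of 2-methoxyphenyl on an oxygen on an aromatic ring gives a 2.5-fold higher number from compound 1 to compound 4 (0.39 log units; beyond the scatter). Among these compounds, this is the first step with only one place changed, and it shows that the group on this oxygen can move the number beyond the scatter. The two groups have equal counts of hydrogen-bond donors and acceptors and no net charge, so those counts do not separate them, and no measured property of the compounds bears on the step.

Still open, as far as these compounds go, is whether the higher number follows the entering dimethylamino group or the loss of the methoxy group, since the two go together in this single step. A plain phenyl or a pyridine ring on the same oxygen would help separate these two readings.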